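Carbonyl substituent variation on the shared core

The source may hold more compounds than are shown below. What is called first, only, known or untested is meant among the compounds shown, and "the series" means these compounds.

Measured so far:
compound 1 `O=C(C1CCCO1)N1CC(c2nc(-c3cccc(Cl)c3)no2)C1` — an assay on HEK293 cells for positive allosteric modulation of metabotropic glutamate receptor 5 (Homo sapiens), read by FLIPR; a higher number here means that more compound is needed for the effect, a lower number that less compound is needed: > 10000 nM, a limit of the assay
compound 2 `CC1CCN(C(=O)N2CC(c3nc(-c4cccc(Cl)c4)no3)C2)C1` — this assay: > 10000 nM, a limit of the assay
compound 3 `O=C(C1CCC(F)(F)CC1)N1CC(c2nc(-c3cccc(Cl)c3)no2)C1` — this assay: 180 nM

Within the data shown here, compound 3 thus gives the only number in this set; the other two values sit at the limit of > 10000 nM in this assay, at which 2 of the 3 values shown sit. Compound 4 `O=C([C@H]1CC2CCC1C2)N1CC(c2nc(-c3cccc(Cl)c3)no2)C1` carries a group of 7 heavy atoms (7 carbon; 2 five-membered non-aromatic rings of carbon only) in place of a group of 8 heavy atoms (6 carbon, 2 fluorine; one six-membered non-aromatic ring of carbon only), on a carbonyl carbon. The steps bearing on this position are an at least 55-fold lower number from compound 1 to compound 3 (1.74 log units; beyond the scatter) and an at least 55-fold lower number from compound 2 to compound 3 (1.74 log units; beyond the scatter), both large and both running to compound 3, yet neither compares two carbon-only rings, so their size cannot simply be carried over. Compound 4 is therefore expected to stay near compound 3 or lose modestly, a 1.9-fold higher number from compound 3 to compound 4 (0.29 log units; within the scatter). The estimate for compound 4 is 350 nM, with a range from 100 nM to 1500 nM.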

Compound 4, half-maximal effective concentration: 74 nM
Beside the measured number, compound 4's estimate is 4.7-fold (0.67 log units) above it, and the stated range ends above it.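

The position on the carbonyl carbon does not depend on fluorine: a group of 2 five-membered non-aromatic rings of carbon only gives a 2.4-fold lower number from compound 3 to compound 4 (0.39 log units; beyond the scatter). Against the rings holding a hetero atom, the gaps are an at least 130-fold lower number from compound 2 to compound 4 (2.13 log units; beyond the scatter) and an at least 130-fold lower number from compound 1 to compound 4 (2.13 log units; beyond the scatter). Both are bounds, since compound 1 and compound 2 each stand at a limit of the assay: the limit of > 10000 nM in this assay, at which 2 of the 4 values shown sit.

Still open, as far as these compounds go, is whether the defined stereocentre of compound 4 matters for this assay. Also open, from the compounds shown here alone, is whether an amine or a carboxylic acid on the carbon-only rings would keep a number of this order.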